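Aryl substituent swap on the shared core: compound 3 to compound 4

A few compounds are considered here, and "the series" means these few. Any claim that something is new, unique, unknown or untested is made for them only; others in the source may bear on it.

Measured compounds:
compound 1 `COc1ccc2c(OCc3nnc4sc(-c5cccn5C)nn34)ccnc2c1`: "not determined" (no result reported) in a functional assay on EBC-1 cells (Homo sapiens) for antiproliferative activity, with a stated time of 72 h; a higher number here means a weaker inhibitor, a lower number a stronger inhibitor
compound 2 `COc1ccc2c(OCc3nnc4sc(-c5cc6ccccc6n5C)nn34)ccnc2c1`: 149 nM
compound 3 `COc1cccc(-c2nn3c(COc4ccnc5cc(OC)ccc45)nnc3s2)c1`: 472 nM

Compound 3 holds the highest of the two numbers in this assay; its nearest neighbour is compound 2, and the step of a 3.2-fold higher number from compound 2 to compound 3 (0.50 log units; beyond the scatter) is modest yet beyond the scatter. Compound 4 `COc1ccc2c(OCc3nnc4sc(-c5ccn(CC6CC6)c5)nn34)ccnc2c1` differs from compound 3 by 1-(cyclopropylmethyl)-1H-pyrrol-3-yl in place of 3-methoxyphenyl on an aromatic carbon. Among the compounds with values here, only that one step bears on the exchange, since compound 1, carrying another five-membered group at the same place, has no result. A change of the aromatic group there moved the number modestly, so a modest shift is expected again, more likely downward toward compound 2, giving the expected step of a 1.6-fold lower number from compound 3 to compound 4 (0.20 log units; within the scatter). Compound 4 is therefore estimated at 300 nM, within a range of 100 nM to 1000 nM.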

Compound 4, half-maximal inhibitory concentration: 351 nM
Beside the measured number, compound 4's estimate is 1.2-fold (0.07 log units) below it; the measured number falls inside the stated range.
By their numbers in this assay, from the lowest: compound 2; then compounds 4 and 3 (each within the scatter of the next).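

In this assay, the position next to the ring sulfur does not separate 1-(cyclopropylmethyl)-1H-pyrrol-3-yl from 3-methoxyphenyl, with a 1.3-fold lower number from compound 3 to compound 4 (0.13 log units; within the scatter). A five-membered aromatic ring with one nitrogen can therefore stand there without matching 1-methyl-1H-indol-2-yl, as a 2.4-fold higher number from compound 2 to compound 4 (0.37 log units; beyond the scatter) shows. No measurement here bears on the reason for either step.

The compounds shown do not separate the fused benzene ring of the indole from its point of attachment or its nitrogen substituent. From the compounds shown here alone, how a carboxylic acid or an amine on the chain at the pyrrole nitrogen would read also remains open.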